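Solubility of a methylamide analogue in the shared series

The source may report more compounds than this note shows. Statements on the series, on what has been measured and on what is new or still open speak of the compounds shown alone.

Measured so far:
compound 1, `Cc1cc(/C=C/C#N)cc(C)c1Oc1cc(Nc2ccc(C#N)cc2)c(N)cc1C(=O)NN`: 2.4 ug/mL
compound 2, `Cc1cc(/C=C/C#N)cc(C)c1Oc1cc(Nc2ccc(C#N)cc2)c(N)cc1C(=O)NCCCO`: 1.01 ug/mL
compound 3, `Cc1cc(/C=C/C#N)cc(C)c1Oc1cc(Nc2ccc(C#N)cc2)c(N)cc1C(=O)OCCC#N`: 0.36 ug/mL

In a physicochemical assay for solubility, read by HPLC, in phosphate buffer, with a stated time of 4 h, at pH 7.4 (a lower number here means a less soluble compound, a higher number a more soluble compound), compound 2 holds the second highest of the three numbers. Its nearest neighbour is compound 1, with the step of a 2.4-fold lower number from compound 1 to compound 2 (0.38 log units; beyond the scatter); the furthest is compound 3, with the step of a 2.8-fold lower number from compound 2 to compound 3 (0.45 log units; beyond the scatter). The unmeasured compound 4, `CNC(=O)c1cc(N)c(Nc2ccc(C#N)cc2)cc1Oc1c(C)cc(/C=C/C#N)cc1C`, differs from compound 2 in one place: hydrogen in place of 2-hydroxyethyl on a saturated chain carbon bound to an amide-type nitrogen. Both measured steps that touch compound 2 replace or trim the group on the carbonyl side, and both gave modest steps, a 2.4-fold lower number from compound 1 to compound 2 (0.38 log units; beyond the scatter) and a 2.8-fold lower number from compound 2 to compound 3 (0.45 log units; beyond the scatter), so every change seen so far in this series has moved the number downward by a modest amount. The change to compound 4 removes the hydroxyl-bearing chain and leaves a methylamide; the writer therefore expects a modest step, a 1.4-fold lower number from compound 2 to compound 4 (0.16 log units; within the scatter), downward rather than upward, possibly near the edge of the scatter. Compound 4 is estimated at 0.7 ug/mL, with a range from 0.25 ug/mL to 2 ug/mL.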

Compound 4, solubility: 8.28 ug/mL
Compound 4: the middle estimate sits 12-fold (1.07 log units) below what was measured, and the stated range ends below it.
By their numbers in this assay, from the lowest: compound 3; then compound 2; then compound 1; then compound 4.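

In this assay, among these compounds, shortening the amide substituent from 3-hydroxypropyl to methyl does not continue the downward run of the earlier steps: it gives an 8.2-fold higher number from compound 2 to compound 4 (0.91 log units; beyond the scatter), so the loss of 2-hydroxyethyl at this position raises the number. Methylamino also outranks the other carbonyl substituents, with a 3.5-fold higher number from compound 1 to compound 4 (0.54 log units; beyond the scatter) and a 23-fold higher number from compound 3 to compound 4 (1.36 log units; beyond the scatter), which places compound 4 highest of the four, and the longer chain of compound 2 does not hold an advantage here. Nothing shown here explains this rise.

The step from compound 2 to compound 4 changes both the chain length and the presence of the hydroxyl, and a plain propyl chain on the amide nitrogen would separate the two. On these data alone, how an ethyl chain, or a chain ending in an amine, would read remains open.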